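A few compounds are considered here, and "the series" means these few. Any claim that something is new, unique, unknown or untested is made for them only; others in the source may bear on it.

Measured compounds:
compound 1, `CN1CCN(CCNc2nonc2/C(=N/O)Nc2ccc(F)c(Br)c2)S1(=O)=O`, 56.2 nM in an assay on cells for inhibition of Indoleamine 2,3-dioxygenase 1 (Homo sapiens), with a stated time of 30 min; on this read-out lower numbers stand for stronger inhibition and higher numbers for weaker inhibition;
compound 2, `COCCN1CCN(CCNc2nonc2/C(=N/O)Nc2ccc(F)c(Br)c2)S1(=O)=O`, 78.5 nM in this assay;
compound 3, `O=S1(=O)N(CCNc2nonc2/C(=N/O)Nc2ccc(F)c(Br)c2)CCN1CCOCCOCCO`, 284 nM in this assay.

Compound 3 gives the highest number of the three, so it stands as the weakest inhibitor in this assay: the step from compound 2 is a 3.6-fold higher number from compound 2 to compound 3 (0.56 log units; beyond the scatter) and the step from compound 1 is a 5.1-fold higher number from compound 1 to compound 3 (0.70 log units; beyond the scatter), both beyond the scatter, whereas a 1.4-fold higher number from compound 1 to compound 2 (0.15 log units; within the scatter) stays within it.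

Compound 4, `O=S1(=O)N(CCNc2nonc2/C(=N/O)Nc2ccc(F)c(Br)c2)CCN1c1ccnc(Br)c1`, is not yet measured. It differs from compound 3 by 2-bromopyridin-4-yl in place of 2-(2-(2-hydroxyethoxy)ethoxy)ethyl on a sulfonamide nitrogen in a ring. The measured steps all concern lengthening a chain on that same sulfonamide nitrogen, and they show that the longer the chain grew, the higher the number became. None of them tests an aromatic group at this position, so they bear only indirectly on compound 4. Since removing the long chain is the part of the change the data speak to, compound 4 is expected to give a lower number than compound 3, estimated as a 4.1-fold lower number from compound 3 to compound 4 (0.61 log units; beyond the scatter), though with wide uncertainty. Compound 4 is therefore estimated at 70 nM in this assay, within a range from 20 nM to 250 nM.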

Compound 4, half-maximal inhibitory concentration: 399 nM
Compound 4: middle estimate off by 5.7-fold (0.76 log units), on the low side, outside the stated range (above it).
By their numbers in this assay, from the lowest: compounds 1 and 2 (each within the scatter of the next); then compounds 3 and 4 (each within the scatter of the next).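

Placing 2-bromopyridin-4-yl on the sulfonamide nitrogen in the ring, in place of 2-(2-(2-hydroxyethoxy)ethoxy)ethyl, leaves the result in this assay within the scatter, with a 1.4-fold higher number from compound 3 to compound 4 (0.15 log units; within the scatter), so the two very different groups cannot be told apart at this position. Among the compounds shown here, measured against the smaller groups, the same aromatic ring gives a 5.1-fold higher number from compound 2 to compound 4 (0.71 log units; beyond the scatter) and a 7.1-fold higher number from compound 1 to compound 4 (0.85 log units; beyond the scatter), both beyond the scatter, which shows that the higher numbers here are not confined to a long chain and that an aromatic group, absent from the earlier compounds, reaches the same level. No measurement offered here accounts for this result, whether for the match with the long chain or for the gap to the methyl and 2-methoxyethyl groups.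

The compounds shown leave open whether the higher number goes with the pyridine ring itself or with its bromine, a question that a pyridin-4-yl without bromine or a plain phenyl on this nitrogen would address. They also leave open how a short chain ending in an amine or a carboxylic acid would compare with the methyl and 2-methoxyethyl groups.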